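Turning One Stereocentre in a Cytotoxic Series

The source may hold more compounds than are shown below. What is called first, only, known or untested is meant among the compounds shown, and "the series" means these compounds.

Values in an ADME assay on L1210 cells (Mus musculus) for cytotoxicity, with a stated time of 48 h; a higher number here means a weaker inhibitor, a lower number a stronger inhibitor:
- Compound 1 `C=C1[C@H](C)CCC[C@]1(C)CC/C(C)=C/CC1=C(O)C(=O)C=C(N[C@H](CO)C(=O)O)C1=O`: 2.6 ug/mL
- Compound 2 `CC1=CCC[C@](C)(CC/C(C)=C/CC2=C(O)C(=O)C=C(N[C@H](CO)C(=O)O)C2=O)[C@@H]1C`: > 10 ug/mL (a limit)
- Compound 3 `CC1=CCC[C@H]2[C@](C)(CC3=C(O)C(=O)C=C(N[C@@H](CO)C(=O)O)C3=O)[C@@H](C)CC[C@]12C`: 3.8 ug/mL

In this assay compound 1 gives 2.6 ug/mL and compound 3 gives 3.8 ug/mL, two values within the scatter of each other. Compound 2 reaches only a limit, > 10 ug/mL.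

The next structure is compound 4 `C=C1[C@H](C)CCC[C@]1(C)CC/C(C)=C/CC1=C(O)C(=O)C=C(N[C@@H](CO)C(=O)O)C1=O`, which relates to compound 1 as follows: the two compounds have the same atoms and bonds and differ only in configuration as drawn: 1 of 4 stereo elements differ; a stereocentre at a saturated chain carbon is drawn R in compound 1 and S in compound 4.

Within the data shown here, the only measured step is an at least 3.8-fold higher number from compound 1 to compound 2 (0.58 log units; beyond the scatter), which lies beyond the scatter. It exchanges one six-membered carbon ring group for another and leaves this stereocentre as drawn, so it bears only indirectly, as a sign that the numbers can move within this small set. Among the measured compounds shown here, no measured step changes this stereocentre alone, and no shift beyond the scatter is therefore foreseen. The estimate is a 1.2-fold higher number from compound 1 to compound 4 (0.06 log units; within the scatter), an expected step that stays small but remains uncertain. Compound 4 is expected at 3 ug/mL, with an estimated range of 1.3 ug/mL to 8 ug/mL.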

Compound 4, half-maximal inhibitory concentration: > 10 ug/mL
Compound 4 was reported as a limit (the forecaster's own chance of this, stated with the estimate: 15%); middle value at least 3.3-fold (0.52 log units) away from the limit.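

The change of this stereocentre from R to S gives an at least 3.8-fold higher number from compound 1 to compound 4 (0.58 log units; beyond the scatter), so the exchange of ring groups in compound 2 is not the only change shown to move the number. The step can be put down to configuration alone, because nothing else separates the pair: the fact that compounds 1 and 4 differ only in the configuration as drawn. Compound 4 is reported only as a limit, and it shares that limit with compound 2: the limit of > 10 ug/mL in this assay, at which 2 of the 4 values shown sit.

Going by these compounds, the true value of compound 4 remains unknown, and with it the full size of the step, which has only a lower bound. Also open, on these data alone, is whether a methyl ester in place of the carboxylic acid would show the same dependence on the configuration at this stereocentre.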